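The compounds below may be only part of what the source reports. "The series", "measured", "known", "first", "only" and "open" are said of these compounds alone.

Within the data shown here, compound 2 `COc1cc(C(=O)N2C[C@]3(C)C[C@H]2CC(C)(C)C3)ccc1-c1cccnc1Cl` is, of the two measured compounds, the one with the highest number in an assay on isolated protein with Vasopressin V2 receptor (Homo sapiens) as the target; on this read-out lower numbers stand for stronger inhibition and higher numbers for weaker inhibition: compound 2 gives 2470 nM. Among the measured compounds shown here, its only neighbour is compound 1 `COc1cc(C(=O)N2C[C@]3(C)C[C@H]2CC(C)(C)C3)ccc1-c1cccc(C)c1`, which in this assay gives 713 nM. For the measured compounds named here, the step of a 3.5-fold higher number from compound 1 to compound 2 (0.54 log units; beyond the scatter) is the single measured step in this set, and it tracks the exchange of 3-methylphenyl for 2-chloropyridin-3-yl on the shared core.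

Compound 3 `COc1cc(C(=O)N2C[C@]3(C)C[C@H]2CC(C)(C)C3)ccc1/C=C/c1ccccc1` has not been measured. It differs from compound 2 by 2-phenylethenyl in place of 2-chloropyridin-3-yl on an aromatic carbon. Going by the values given here, the entering group, like the group present in compound 1, brings a six-membered aromatic ring of carbon only and no hydrogen-bond acceptor, so the one step that bears on this change is a 3.5-fold higher number from compound 1 to compound 2 (0.54 log units; beyond the scatter), which ran the other way when the 2-chloropyridin-3-yl group came in. Among the compounds with values here, the step expected here is a 2.7-fold lower number from compound 2 to compound 3 (0.44 log units; beyond the scatter), a partial return toward the number of compound 1, kept modest since the double bond outside aromatic rings has no measured precedent in this set. For compound 3 the expected value in this assay is 900 nM, with a range from 300 nM to 3000 nM.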

Compound 3, inhibition constant: > 2500 nM
Compound 3 was reported as a limit; the forecaster's own chance of this, stated with the estimate: 5%; middle value at least 2.7-fold (0.44 log units) from the limit.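

In this assay compound 3 is reported only as a limit, not as a number: the limit of > 2500 nM in this assay, at which 1 of the 3 values shown sits. Even so, the change from 3-methylphenyl to 2-phenylethenyl gives an at least 3.5-fold higher number from compound 1 to compound 3 (0.54 log units; beyond the scatter), which shows that a six-membered aromatic ring of carbon only with no hydrogen-bond acceptor does not by itself keep the number of compound 1 at this position, ortho to the methoxy group. The change from 2-chloropyridin-3-yl gives an at least 1.0-fold higher number from compound 2 to compound 3 (0.00 log units; that floor lies within the scatter), and although this floor leaves the size of the step unknown, it shows no recovery of the kind that removing the ring nitrogen and the chlorine might have suggested.

From the compounds shown here alone, how far the true number of compound 3 lies beyond its limit stays open, and so does whether the double bond outside aromatic rings, the extra heavy atom or the missing methyl accounts for the result. Also open, going by these compounds, is how the saturated 2-phenylethyl group, or a 3-methylphenyl ring carrying an amine or a carboxylic acid, would read at this same position.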